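A few compounds are considered here, and "the series" means these few. Any claim that something is new, unique, unknown or untested is made for them only; others in the source may bear on it.

Of the compounds shown here, three have been measured so far: compound 1 (`COc1cc(-c2cc(C(=O)/C=C/c3ccc(Cl)cc3)nc3cc(-c4ccccc4)nn23)cc(OC)c1OC`), compound 2 (`COc1ccc(-c2cc(C(=O)/C=C/c3ccc(Cl)cc3)nc3cc(-c4ccccc4)nn23)cc1OC`) and compound 3 (`COc1ccc(-c2cc(C(=O)/C=C/c3cc(OC)c(OC)c(OC)c3)nc3cc(-c4ccccc4)nn23)cc1OC`). In an ADME assay on HEK293 cells (Homo sapiens) for antiproliferative activity, read by MTT assay, with a stated time of 24 h (on this read-out higher numbers stand for weaker inhibition and lower numbers for stronger inhibition), compound 1 gives 53900 nM; compound 2 gives 39100 nM in the same run, and compound 3 gives 46800 nM there. Compound 2 stands within the scatter of both its neighbours, as the two steps show: a 1.4-fold lower number from compound 1 to compound 2 (0.14 log units; within the scatter), and a 1.2-fold higher number from compound 2 to compound 3 (0.08 log units; within the scatter) as well. Compound 4 (`COc1ccc(-c2cc(/C=C/C(=O)c3ccc(Cl)cc3)nc3cc(-c4ccccc4)nn23)cc1OC`) is not yet measured; it differs from compound 2 in that 2-((4-chlorophenyl)carbonyl)ethenyl in place of (2-(4-chlorophenyl)ethenyl)carbonyl on an aromatic carbon is the change. Among the compounds with values here, no measured step bears directly on this rearrangement of the chain; the two known steps, both within the scatter, concern a methoxy group and the aryl group on the chain. On that basis compound 4 is expected to show a 1.0-fold higher number from compound 2 to compound 4 (0.01 log units; within the scatter) in this assay, nothing beyond the scatter. Compound 4 is accordingly estimated at 40000 nM with a range from 18000 nM to 90000 nM in that assay.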

Compound 4, half-maximal inhibitory concentration: 44100 nM
The estimate for compound 4 lay 1.1-fold (0.04 log units) below the measured number; the range from low to high includes it.
By their numbers in this assay, from the lowest: compounds 2, 4, 3 and 1 (each within the scatter of the next).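

In this assay the change from (2-(4-chlorophenyl)ethenyl)carbonyl to 2-((4-chlorophenyl)carbonyl)ethenyl on this aromatic carbon gives a 1.1-fold higher number from compound 2 to compound 4 (0.05 log units; within the scatter) and so shows that reversing the order of carbonyl and ethenyl, with the same atoms joined differently, leaves the number within the scatter here. No available evidence accounts for this result.

On these data alone, whether the reversed chain would behave the same with 3,4,5-trimethoxyphenyl in place of 4-chlorophenyl remains open. So does whether an amine or a carboxylic acid at this position would move the number beyond the scatter.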